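The compounds below may be only part of what the source reports. "The series", "measured", "known", "first", "only" and "open" are said of these compounds alone.

The series shares the core shown in compound 1 `CCN(c1ccc(C#N)c(Cl)c1)c1cc(-c2cncnc2)ccc1C`, which carries pyrimidin-5-yl. In a functional assay on CWR22R cells (Homo sapiens) for antiproliferative activity, read by CCK-8 assay, with a stated time of 6 days (a higher number here means a weaker inhibitor, a lower number a stronger inhibitor), compound 1 gives only a limit of the assay, > 30000 nM. Compound 2 `CCN(c1ccc(C#N)c(Cl)c1)c1cc(-c2ccccc2)ccc1C` carries phenyl in its place. In this assay compound 2 likewise gives only a limit, > 30000 nM. The step that the two limits leave unreadable from compound 1 to compound 2 therefore cannot be read. Compound 3 `CCN(c1ccc(C#N)c(Cl)c1)c1cc(C2=CCCCC2)ccc1C` carries cyclohex-1-en-1-yl; in this assay compound 3 has no result, "not determined" (no result reported), so it stands at no number of its own. The two other values shown in this assay are both limits (the limit of > 30000 nM in this assay, at which 2 of the 3 values shown sit).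

Compound 4 `CCN(c1ccc(C#N)c(Cl)c1)c1cc(-c2cccnc2)ccc1C` differs from compound 3 by one change (pyridin-3-yl in place of cyclohex-1-en-1-yl on an aromatic carbon). Within the data shown here, the only measured step of the same kind, an exchange of the ring on the same aromatic carbon, is the one from compound 1 to compound 2, and it is unreadable because both of its ends sit at the limit of > 30000 nM in this assay, at which 2 of the 3 values shown sit. Among the measured compounds shown here, no step on this carbon has yet yielded a number, so nothing here points to a rise or a fall in this assay. Compound 4 is expected most likely to be reported only as a limit as well, because compound 1 and compound 2 both sit at the limit of > 30000 nM in this assay, at which 2 of the 3 values shown sit. The estimate for compound 4 in this assay is 30000 nM, within 10000 nM to 100000 nM.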

Compound 4, half-maximal inhibitory concentration: 2000 nM
The estimate for compound 4 lay 15-fold (1.18 log units) above the measured number; measured number outside the range, below it.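

In this assay the ring on this aromatic carbon, meta to a large group and para to a methyl group, now gives its first readable steps: pyridin-3-yl in place of phenyl gives an at least 15-fold lower number from compound 2 to compound 4 (1.17 log units; beyond the scatter) and pyridin-3-yl in place of pyrimidin-5-yl gives an at least 15-fold lower number from compound 1 to compound 4 (1.17 log units; beyond the scatter) (both large and beyond the scatter). A ring nitrogen alone does not go with the lower number in these compounds: pyrimidin-5-yl also holds ring nitrogen, yet compound 1 stays at a limit of the assay. Both steps start from a limit rather than a number, so their full size stays unknown: the limit of > 30000 nM in this assay, at which 2 of the 4 values shown sit.

The step between compound 1 and compound 2 still cannot be read, and compound 3 has no result, so the ring with no aromatic character gives no comparison with pyridin-3-yl. Open, from the compounds shown here alone, is how far the number for compound 4 depends on where the nitrogen stands in the ring, as pyridin-4-yl or pyridin-2-yl would show, and whether an amine or a methoxy group on the pyridin-3-yl ring would move it further.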